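The source may report more compounds than this note shows. Statements on the series, on what has been measured and on what is new or still open speak of the compounds shown alone.

Compound 1 `CCC[C@@H](N)C(=O)NCc1ccccc1` carries a propyl group on the carbon that bears the amine and the carbonyl, and compound 2 `C=CCOCC(N)C(=O)NCc1ccccc1` an allyloxymethyl group in that place. In a functional assay on the whole organism (strain NMRI) for inhibition, with Mus musculus as the target, in the formalin test, with a stated time of 30 min (a higher number here means that more compound is needed for the effect, a lower number that less compound is needed), compound 1 gives 35 mg/kg. In this assay compound 2 gives 75 mg/kg. Compound 3 `CCCC[C@@H](N)C(=O)NCc1ccccc1` lengthens the propyl of compound 1 to a butyl. In this assay compound 3 reaches only a limit of the assay, > 71 mg/kg, so no number is known for it; this is the limit of > 71 mg/kg in this assay, at which 1 of the 3 values shown sits. Among the compounds with values here, the only step that touches compound 3 is an at least 2.0-fold higher number from compound 1 to compound 3 (0.30 log units; that floor lies within the scatter), a step whose floor lies within the usual scatter, so it says no more than that compound 3 is not better than compound 1.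

Compound 4 `CC(C)(C)[C@@H](N)C(=O)NCc1ccccc1` differs from compound 3 as follows: tert-butyl in place of butyl on a saturated chain carbon bound to an amine nitrogen and a carbonyl carbon. Within the data shown here, no measured step bears directly on this rearrangement of the same four carbons. The expectation rests on compound 3 having reached only a limit of the assay. It also rests on compound 1, which gives 35 mg/kg as the best value in the set. The step is estimated as an at least 1.1-fold lower number from compound 3 to compound 4 (0.07 log units; that floor lies within the scatter), with no confident direction. Compound 4 is therefore expected to give about 60 mg/kg in this assay, within a range from 25 mg/kg to 150 mg/kg.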

Compound 4, dose for half-maximal effect: > 22 mg/kg
Compound 4: no number, only a limit; the forecaster's own chance of this, stated with the estimate: 45%; the middle value lies beyond the limit too.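

In this assay compound 4 reaches only a limit, > 22 mg/kg, so its steps to compound 3 and to compound 1 cannot be read. The compounds shown leave open whether tert-butyl in place of butyl or propyl changes the dose needed at all.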